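The compounds below may be only part of what the source reports. "The series", "measured", "known", "first", "only" and "open" are said of these compounds alone.

Measured so far in an assay on HEK293 cells for inhibition of solute carrier family 22 member 12 (Homo sapiens); on this read-out higher numbers stand for weaker inhibition and lower numbers for stronger inhibition:
- compound 1 `O=S(=O)(CSc1nnc(Br)n1Cc1ccc(Br)c2ccccc12)Nc1cccnc1`: 32 nM
- compound 2 `O=S(=O)(CSc1nnc(Br)n1Cc1ccc(Br)c2ccccc12)Nc1ccc(Cl)nc1`: 1940 nM

Compound 2 stands at the highest of the two numbers in this assay; its nearest neighbour is compound 1, and the step of a 61-fold higher number from compound 1 to compound 2 (1.78 log units; beyond the scatter) lies well beyond the scatter. Compound 3 `O=S(=O)(CSc1nnc(Br)n1Cc1ccc(Br)c2ccccc12)Nc1ccc(Cl)nc1Cl` differs from compound 2 by chloro in place of hydrogen on an aromatic carbon. Among the measured compounds shown here, the only measured step that bears on this change is a 61-fold higher number from compound 1 to compound 2 (1.78 log units; beyond the scatter), a large weakening when the first chloro entered the same ring. A second chloro entering next to the ring nitrogen is not covered by any measured pair, so the size of its effect is open. Taking the large step from compound 1 to compound 2 as the only guide, a further, smaller weakening is expected for compound 3, with the possibility that no change beyond the scatter appears. The estimated step is a 2.3-fold higher number from compound 2 to compound 3 (0.37 log units; beyond the scatter). Compound 3 is therefore expected to give about 4500 nM in this assay, within a range from 1200 nM to 18000 nM.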

Compound 3, half-maximal inhibitory concentration: 1660 nM
For compound 3 the middle estimate is 2.7-fold (0.43 log units) above the measured one, and the stated range covers the measured number.
By their numbers in this assay, from the lowest: compound 1; then compounds 3 and 2 (each within the scatter of the next).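

In this assay, chloro in place of hydrogen on the aromatic carbon next to the ring nitrogen, ortho to a large group, gives a 1.2-fold lower number from compound 2 to compound 3 (0.07 log units; within the scatter), so this position accepts chloro on the 6-chloropyridin-3-yl ring with no change that can be read. The large step to the dichloro compound remains, at a 52-fold higher number from compound 1 to compound 3 (1.71 log units; beyond the scatter), so the second chloro neither restores what pyridin-3-yl gives nor adds to the weakening seen with the first chloro. Nothing at hand gives a reason for this pattern.

Open, from the compounds shown here alone, is whether this chloro alone on the pyridin-3-yl ring, without the other chloro, would leave the number where it is. Also open, going by these compounds, is how a methyl group, a methoxy group or an amine would read at this position.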